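Working notes: from compound 3 to compound 4

This account rests on a few compounds, and the source may have more. Where it says the series, first, only, none or still open, it means among the compounds named here.

In a functional assay on MCF7 cells (Homo sapiens) for antiproliferative activity, read by MTT assay, with a stated time of 72 h (on this read-out lower numbers stand for stronger inhibition and higher numbers for weaker inhibition), compound 3 `CCN1CCN(c2cc(C)c3cc(NC(=O)c4cc(Cl)cc(Cl)c4)ccc3n2)CC1` gives 6090 nM and holds the middle of three numbers, although compound 1 `CCN1CCN(c2cc(C)c3cc(NC(=O)c4cccc(Cl)c4)ccc3n2)CC1` at 3820 nM stays within the scatter of it (a 1.6-fold higher number from compound 1 to compound 3 (0.20 log units; within the scatter)). Compound 2 `CCN1CCN(c2cc(C)c3cc(NC(=O)c4ccccc4F)ccc3n2)CC1` gives the highest number (32600 nM). Compound 4 `CCN1CCN(c2cc(C)c3cc(NC(=O)c4ccccc4Cl)ccc3n2)CC1` differs from compound 3 by 2-chlorophenyl in place of 3,5-dichlorophenyl on a carbonyl carbon. Compound 2, with its 2-fluorophenyl, is the nearest measured case, set apart by a 5.4-fold lower number from compound 2 to compound 3 (0.73 log units; beyond the scatter) and by an 8.5-fold higher number from compound 1 to compound 2 (0.93 log units; beyond the scatter). Chloro in place of fluoro there is unmeasured, so a smaller upward step is expected in this assay. The estimated step is a 2.3-fold higher number from compound 3 to compound 4 (0.36 log units; beyond the scatter) overall. Compound 4 is estimated at 14000 nM (expected range 5000 nM to 35000 nM).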

Compound 4, half-maximal inhibitory concentration: > 50000 nM
Compound 4 ended at the assay's limit; the forecaster's own chance of this, stated with the estimate: 5%; middle value at least 3.5-fold (0.55 log units) from the limit.
By their numbers in this assay, from the lowest: compounds 1 and 3 (each within the scatter of the next); then compound 2. At a limit, above all of these: compound 4.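

In this assay compound 4 gives a limit of the assay, not a number: the limit of > 50000 nM in this assay, at which 1 of the 4 values shown sits. With 2-chlorophenyl on the carbonyl carbon, the series shows its first large step, an at least 13-fold higher number from compound 1 to compound 4 (1.11 log units; beyond the scatter), against 3-chlorophenyl, and an at least 8.2-fold higher number from compound 3 to compound 4 (0.91 log units; beyond the scatter) against 3,5-dichlorophenyl. Against 2-fluorophenyl the step is an at least 1.5-fold higher number from compound 2 to compound 4 (0.18 log units; that floor lies within the scatter), so chloro in place of fluoro cannot be ranked, though both groups sit at the high end.

As far as these compounds go, how far compound 4 lies past its limit stays open. So does how an unsubstituted phenyl, or a phenyl carrying an amine or a carboxylic acid, would read at this carbonyl carbon.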